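This account rests on a few compounds, and the source may have more. Where it says the series, first, only, none or still open, it means among the compounds named here.

Compound 3 `NCCCC[C@H](NC(=O)CN(c1nc(Cl)nc2[nH]cnc12)C1CC1)C(=O)O` stands highest of the three compounds measured in a functional assay on the whole organism (Tail, strain ICR) with Mus musculus as the target, in the tail flick test, with a stated time of 60 min, at a dose of 25 umol/kg by the oral route (on this read-out higher numbers stand for a stronger effect at the one dose given and lower numbers for a weaker effect), where compound 3 gives 53.8%. Compound 1 `O=C(CN(c1nc(Cl)nc2[nH]cnc12)C1CC1)N[C@@H](CO)C(=O)O` gives 39.8% in this assay, and compound 2 `O=C(O)CNC(=O)CN(c1nc(Cl)nc2[nH]cnc12)C1CC1` gives 38.9%; the step of a number 0.9 percentage points lower from compound 1 to compound 2 (within the scatter) is within the scatter, whereas a number 14 percentage points higher from compound 1 to compound 3 (beyond the scatter) and a number 14.9 percentage points higher from compound 2 to compound 3 (beyond the scatter) both carry beyond it, so compound 3 is set apart from the other two.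

Compound 4 `CC(C)C[C@H](NC(=O)CN(c1nc(Cl)nc2[nH]cnc12)C1CC1)C(=O)O` is not yet measured. It differs from compound 3 by isopropyl in place of 3-aminopropyl on a saturated chain carbon, two bonds along the chain from an amide-type nitrogen and a carbonyl carbon. Within the data shown here, none of the measured steps exchanges the 3-aminopropyl for an isopropyl, so no step bears directly on this change. What the numbers show is that compound 3, with its 4-aminobutyl, sits above compound 1 and compound 2, which carry a hydroxymethyl or a hydrogen at that carbon; compound 4 keeps a chain of similar length but without the amine. The account therefore expects this assay to give compound 4 a number somewhat below compound 3, with the step of a number 9.8 percentage points lower from compound 3 to compound 4 (within the scatter) estimated to be modest, though it may fall within the scatter. For compound 4 the estimate in this assay is 44%, with a range from 30% to 58%.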

Compound 4, a percentage reported as activity, at one dose (the size of the read-out at that dose, not a potency): 36.4%
Beside the measured number, compound 4's estimate is 7.6 percentage points above it; measured number inside the range.
By their numbers in this assay, from the lowest: compounds 4, 2 and 1 (each within the scatter of the next); then compound 3.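

In this assay, the amine-bearing side chain proves to matter at this position: exchanging 3-aminopropyl for isopropyl, two bonds along the chain from the amide-type nitrogen and the carbonyl carbon, gives a step beyond the scatter (a number 17.4 percentage points lower from compound 3 to compound 4 (beyond the scatter)). The isobutyl chain of compound 4 does not separate from the hydrogen of compound 2 (a number 2.5 percentage points lower from compound 2 to compound 4 (within the scatter)) or from the hydroxymethyl of compound 1 (a number 3.4 percentage points lower from compound 1 to compound 4 (within the scatter)), both steps lying within the scatter, so among these four compounds only the 4-aminobutyl of compound 3 stands apart, and a carbon side chain alone does not reproduce its number. Nothing measured on these compounds speaks to what lies behind this difference.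

The compounds shown leave open whether the amine or the unbranched chain carries the higher number, which a straight butyl or a 4-hydroxybutyl chain at this carbon could separate. They also leave open how the result depends on the distance of the amine from the chain carbon, which a shorter or longer aminoalkyl chain, or a guanidine at the chain end, would test.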